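Swapping the amine substituent on compound 3: an estimate

A few compounds are considered here, and "the series" means these few. Any claim that something is new, unique, unknown or untested is made for them only; others in the source may bear on it.

Compound 1 `COc1cc(OC)c(/C=C/SCc2ccc(OC)c(N)c2)c(OC)c1` gives 50 nM in a functional assay on DU-145 cells (Homo sapiens) for cytotoxicity, read by trypan blue exclusion, with a stated time of 96 h; on this read-out lower numbers stand for stronger inhibition and higher numbers for weaker inhibition. Compound 2 `COC(=O)CNc1cc(CS(=O)(=O)/C=C/c2cc(OC)c(OC)c(OC)c2)ccc1OC` gives 75000 nM. Compound 3 `COC(=O)C(C)(C)Nc1cc(CS(=O)(=O)/C=C/c2c(OC)cc(OC)cc2OC)ccc1OC` gives 2500 nM.

Compound 3 stands second highest of the three numbers, well clear of compound 1 on the low side and well clear of compound 2 on the high side. Compound 4 `COc1cc(OC)c(/C=C/S(=O)(=O)Cc2ccc(OC)c(NC(C(=O)O)c3ccc(F)cc3)c2)c(OC)c1` differs from compound 3 in one spot: carboxy(4-fluorophenyl)methyl in place of 1-(methoxycarbonyl)-1-methylethyl on a nitrogen on an aromatic ring. Among the compounds with values here, no measured pair tests this exact change, so the expectation rests on the spread already seen among the three compounds. The step from compound 3 to compound 4 is expected to be a 3.2-fold higher number from compound 3 to compound 4 (0.51 log units; beyond the scatter), toward a higher number and beyond the scatter, though not as far as compound 2. Compound 4 is therefore estimated at 8000 nM, within 1500 nM to 40000 nM.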

Compound 4, half-maximal inhibitory concentration: 150 nM
For compound 4 the middle estimate is 53-fold (1.73 log units) above the measured one; the measured number lies below the stated range.
By their numbers in this assay, from the lowest: compound 1; then compound 4; then compound 3; then compound 2.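

The group on the nitrogen on the aromatic ring strongly affects inhibition: carboxy(4-fluorophenyl)methyl in place of 1-(methoxycarbonyl)-1-methylethyl gives a 17-fold lower number from compound 3 to compound 4 (1.22 log units; beyond the scatter), which means stronger inhibition. This position therefore tolerates a group carrying both an aromatic ring and a free carboxylic acid. Nothing shown explains the gain.

The change alters the ring, the fluorine and the ester-to-acid switch at once, so the compounds shown cannot separate their contributions. An unsubstituted phenyl in place of the 4-fluorophenyl, or the methyl ester of the carboxylic acid, would help to separate them.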